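Cyclopropyl for Cyano on the Arylpiperazine of Compound 3

The source may hold more compounds than are shown below. What is called first, only, known or untested is meant among the compounds shown, and "the series" means these compounds.

Three compounds were measured in a functional assay for antagonist activity at Alpha-1A adrenergic receptor (Oryctolagus cuniculus); on this read-out lower numbers stand for tighter binding and higher numbers for weaker binding. Compound 1 `COc1ccccc1N1CCN(CCCNc2ncc(C#N)cc2C(=O)N(C)C)CC1` gives 0.794 nM, compound 2 `COc1ccccc1N1CCN(CCCOc2ccccc2C(=O)N(C)C)CC1` gives 3.98 nM, and compound 3 `CN(C)C(=O)c1cccnc1NCCCN1CCN(c2ccccc2C#N)CC1` gives 2 nM. Compound 3 thus stands second highest of the three numbers: its value and that of compound 2 lie within the scatter of each other, while compound 1 sits beyond the scatter on the lower side. The unmeasured compound 4 `CN(C)C(=O)c1cccnc1NCCCN1CCN(c2ccccc2C2CC2)CC1` differs from compound 3 in one place: cyclopropyl in place of cyano on an aromatic carbon. For the measured compounds named here, no measured pair shows this same change, so the step is judged from the spread of the three values alone. The step expected is a 2.5-fold higher number from compound 3 to compound 4 (0.40 log units; beyond the scatter), a modest move toward higher numbers that may not clear the scatter. Compound 4 is estimated at 5 nM, within 1.5 nM to 16 nM.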

Compound 4, dissociation constant: 0.631 nM
Compound 4: middle estimate off by 7.9-fold (0.90 log units), on the high side; measured number outside the range, below it.
By their numbers in this assay, from the lowest: compounds 4 and 1 (each within the scatter of the next); then compounds 3 and 2 (each within the scatter of the next).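

In this assay, cyclopropyl in place of cyano on this aromatic carbon, ortho to a large group, gives a 3.2-fold lower number from compound 3 to compound 4 (0.50 log units; beyond the scatter). For this pair, then, the hydrogen-bond acceptor of the cyano group is not needed for a low number, and a three-membered ring of carbon only is accepted at this place. Nothing available here accounts for the size or direction of this step.

The compounds shown leave open whether cyclobutyl or isopropyl on this aromatic carbon would keep the lower number. They also leave open whether the same change would give a similar step on another core.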